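Compound 3 and a swap of halogenated phenyl groups

The source may hold more compounds than are shown below. What is called first, only, known or untested is meant among the compounds shown, and "the series" means these compounds.

Measured in a functional assay on MDA-MB-231 cells (Homo sapiens) for antiproliferative activity, read by MTT assay, with a stated time of 72 h; on this read-out higher numbers stand for weaker inhibition and lower numbers for stronger inhibition:
compound 1 `CCNC(=O)CCc1cccc2c1B(O)OC2`: > 100000 nM (a limit of the assay)
compound 2 `O=C(CCc1cccc2c1B(O)OC2)NC1CCCCC1`: > 100000 nM (a limit of the assay)
compound 3 `O=C(CCc1cccc2c1B(O)OC2)Nc1ccc(Br)cc1`: 5300 nM

Within the data shown here, compound 3 is the only compound with a number in this assay. The other two compounds sit at the limit of > 100000 nM in this assay, at which 2 of the 3 values shown sit.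

The next compound to be measured is compound 4 `O=C(CCc1cccc2c1B(O)OC2)Nc1cccc(I)c1`, with 3-iodophenyl in place of 4-bromophenyl on an amide-type nitrogen.

Among the measured compounds shown here, two measured steps bear on this change: an at least 18-fold lower number from compound 1 to compound 3 (1.27 log units; beyond the scatter), with 4-bromophenyl in place of ethyl, and an at least 18-fold lower number from compound 2 to compound 3 (1.27 log units; beyond the scatter), with 4-bromophenyl in place of cyclohexyl. Both are large. The third, a step that the two limits leave unreadable from compound 1 to compound 2, offers no size to work with. No measured step exchanges one substituted phenyl group for another, so the size of this change is not directly shown.

Compound 4 keeps a phenyl group, so its value is expected to lie near that of compound 3 at 5300 nM. The expected result is a 1.1-fold lower number from compound 3 to compound 4 (0.03 log units; within the scatter), with no step beyond the scatter and no direction foreseen. For compound 4 the estimated value is 5000 nM, with an expected range of 1500 nM to 20000 nM.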

Compound 4, half-maximal inhibitory concentration: 5300 nM
Compound 4: the middle estimate sits 1.1-fold (0.03 log units) below what was measured; the range from low to high includes it.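

In this assay the exchange of 4-bromophenyl for 3-iodophenyl on the amide-type nitrogen gives no change at the digits printed from compound 3 to compound 4 (within the scatter) and shows that this position accepts a second halogenated phenyl group with no readable loss. The large step is therefore no longer tied to compound 3 alone, since the new compound shows an at least 18-fold lower number from compound 2 to compound 4 (1.27 log units; beyond the scatter) and also an at least 18-fold lower number from compound 1 to compound 4 (1.27 log units; beyond the scatter) in the same read-out. Both steps start from a value that is a limit of the assay, not a number:
the limit of > 100000 nM in this assay, at which 2 of the 4 values shown sit.

The halogen and its printed position both differ between compound 3 and compound 4, and the compounds shown do not separate the two. Also open, on these data alone, is how an unsubstituted phenyl group, or a phenyl group carrying a methoxy group or a carboxylic acid in place of the halogen, would read at this position.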